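Compound 3 to compound 4: exchanging one ring group

The source may hold more compounds than are shown below. What is called first, only, known or untested is meant among the compounds shown, and "the series" means these compounds.

In a functional assay on A549 cells (Homo sapiens) for antiproliferative activity, read by MTT assay, with a stated time of 72 h (a higher number here means a weaker inhibitor, a lower number a stronger inhibitor), compound 1 `O=C(N/N=C/c1ccc(F)cc1)Nc1ccc(Oc2ccnc3[nH]ccc23)c(F)c1` gives 680 nM and compound 2 `O=C(N/N=C/c1ccc(F)cc1Cl)Nc1ccc(Oc2ccnc3[nH]ccc23)c(F)c1` gives 10 nM. Compound 3 `O=C(N/N=C/c1cc(Br)c(O)c(Br)c1)Nc1ccc(Oc2ccnc3[nH]ccc23)c(F)c1` has the highest number of the three, 16200 nM, which makes it the weakest inhibitor so far.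

Compound 4 `CN(C)CCn1cccc1/C=N/NC(=O)Nc1ccc(Oc2ccnc3[nH]ccc23)c(F)c1` keeps the shared core but carries 1-(2-(dimethylamino)ethyl)-1H-pyrrol-2-yl in place of 3,5-dibromo-4-hydroxyphenyl on a carbon with a double bond to nitrogen.

Changes at this same carbon have been large, with a 24-fold higher number from compound 1 to compound 3 (1.38 log units; beyond the scatter) and a 1600-fold higher number from compound 2 to compound 3 (3.21 log units; beyond the scatter). A single chloro also gave a 68-fold lower number from compound 1 to compound 2 (1.83 log units; beyond the scatter), so small edits to the ring matter here too. No pyrrole has been measured, which leaves the size of the next step uncertain. Still, compound 3 lies far above both neighbours, so removing its group should more likely lower the number than raise it. The expected change is large and downward, a 41-fold lower number from compound 3 to compound 4 (1.61 log units; beyond the scatter). Compound 4 is estimated at 400 nM, with an expected range of 40 nM to 4000 nM.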

Compound 4, half-maximal inhibitory concentration: "not active" (no number reported)
The entry for compound 4 holds no number; no gap can be computed for the estimate.
By their numbers in this assay, from the lowest: compound 2; then compound 1; then compound 3.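

Among the compounds shown here, compound 4 is reported as "not active" with no number, so no step from compound 1, compound 2 or compound 3 to compound 4 can be read. Going by these compounds, how far 1-(2-(dimethylamino)ethyl)-1H-pyrrol-2-yl moves the number stays open. Nothing measured here accounts for this entry.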